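The source may report more compounds than this note shows. Statements on the series, on what has been measured and on what is new or still open speak of the compounds shown alone.

Measured compounds:
- Compound 1, `CC(=O)/C=C1\C(=O)Nc2ccc(Cl)cc21`: 54700 nM
- Compound 2, `O=C1Nc2ccccc2/C1=N/Nc1cccc(Cl)c1`: 46800 nM

Both compounds were tested in an assay on isolated protein for inhibition of Tryptophan 2,3-dioxygenase (Homo sapiens) (on this read-out lower numbers stand for stronger inhibition and higher numbers for weaker inhibition), where compound 1 gives 54700 nM and compound 2 gives 46800 nM. Compound 1 has the highest number of the two, but the gap to compound 2 lies within the scatter of repeated measurements, so the two compounds cannot be told apart on these data. Both numbers are high, meaning weak inhibition.

Compound 3, `CC(=O)CC(=O)/C=C1\C(=O)Nc2ccc(Cl)cc21`, has not yet been measured. It differs from compound 1 in one place: acetyl in place of hydrogen on a saturated chain carbon bound to a carbonyl carbon. Among the measured compounds shown here, no pair of measured compounds shows this kind of change, so there is no direct precedent for its effect. Because compound 1 sits at 54700 nM and the change adds only a small, uncharged group on the chain, the expectation is a step in this assay of no more than the scatter, in either direction. The estimated step of a 1.2-fold lower number from compound 1 to compound 3 (0.08 log units; within the scatter) is therefore close to none. Compound 3 is expected to give about 45000 nM, within a range from 15000 nM to 140000 nM.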

Compound 3, half-maximal inhibitory concentration: 39900 nM
The estimate for compound 3 lay 1.1-fold (0.05 log units) above the measured number; measured number inside the range.
By their numbers in this assay, from the lowest: compounds 3, 2 and 1 (each within the scatter of the next).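

In this assay, placing an acetyl in place of hydrogen on a saturated chain carbon bound to a carbonyl carbon comes to a 1.4-fold lower number from compound 1 to compound 3 (0.14 log units; within the scatter), so this first look at the position shows that a group of 3 heavy atoms can be added here with no change that stands out from the scatter of repeated measurements. The same difference can be read as methyl becoming 2-oxopropyl, and this longer side chain leaves compound 3 at 39900 nM in this assay, still a high number that stands for weak inhibition, so the acetyl brings no gain that can be claimed on these data. No measurement is available here that would explain this result.

From the compounds shown here alone, whether an amine or a carboxylic acid on this chain carbon, or a still longer chain, would move the number beyond the scatter remains open. A single step also leaves open whether this position can affect inhibition of the enzyme at all, or whether its apparent tolerance extends to groups larger than acetyl.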